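From 3-fluorophenyl to 4-chlorophenyl on the shared core

The source may report more compounds than this note shows. Statements on the series, on what has been measured and on what is new or still open speak of the compounds shown alone.

Compound 1 `CC(Nc1ccc(Cl)cc1Cl)C(=O)NCc1ccc(F)cc1`: > 100000 nM (a limit, not a number)
Compound 2 `CC(Oc1ccc(Cl)cc1Cl)C(=O)NCc1cccc(F)c1`: 27000 nM

Both compounds were tested in an ADME assay on CHO cells (Cricetulus griseus) for cytotoxicity, read by LDH release; on this read-out lower numbers stand for stronger inhibition and higher numbers for weaker inhibition. For the measured compounds named here, there, compound 2 gives 27000 nM, the only true number available so far. The entry for compound 1, > 100000 nM, is a limit of this assay and not a number. Going by the values given here, compound 2 therefore has no numerical neighbour to be ranked against, and no step between measured compounds differing in one place is available.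

The next compound to be measured is compound 3 `CC(Oc1ccc(Cl)cc1Cl)C(=O)NCc1ccc(Cl)cc1`. It carries 4-chlorophenyl in place of 3-fluorophenyl on a saturated chain carbon bound to an amide-type nitrogen. Among the compounds with values here, the expectation rests on compound 2 at 27000 nM, since the change is confined to this one group and no measured step shows its size. Only a small move towards a lower number is expected, and the estimated step of a 1.4-fold lower number from compound 2 to compound 3 (0.13 log units; within the scatter) stays within the usual scatter. A reading at the limit of this assay cannot be ruled out. In this assay the estimated value for compound 3 is 20000 nM, with an expected range from 7000 nM to 60000 nM.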

Compound 3, half-maximal inhibitory concentration: 39000 nM
Compound 3: middle estimate off by 2.0-fold (0.29 log units), on the low side; low and high end bracket the measured number.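

In this assay, for the compounds shown here, putting 4-chlorophenyl in place of 3-fluorophenyl on a saturated chain carbon bound to an amide-type nitrogen gives a 1.4-fold higher number from compound 2 to compound 3 (0.16 log units; within the scatter), the only step at this position so far. The two phenyl groups, which differ in their halogen and in where it sits, therefore cannot be told apart in this read-out, and the change leaves compound 2 and compound 3 both with true numbers. Compound 1 alone sits at the limit, and its entry is a limit and not a number: the limit of > 100000 nM in this assay, at which 1 of the 3 values shown sits.

Whether a carboxylic acid or a pyridine ring at this same position would give a step beyond the scatter remains open, since both groups shown here are halogen-bearing phenyl rings of the same size. Compound 1 differs from compound 2 and from compound 3 in more than one place, and the compounds shown hold no pair that sets the oxygen link of compound 2 and compound 3 directly against the nitrogen link of compound 1.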